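Swapping Hydroxy for Chloro on an Adenosine Receptor Ligand

The source may report more compounds than this note shows. Statements on the series, on what has been measured and on what is new or still open speak of the compounds shown alone.

Of the compounds shown here, three built on one shared core have been measured in an assay on CHO cells for displacement of a labelled ligand from adenosine receptor A1 (Homo sapiens), read by scintillation counting, with a stated time of 3 h; a lower number here means a stronger inhibitor, a higher number a weaker inhibitor. Compound 1 `CCCn1c(-c2ccccc2)nc2c(NC3CCCC3)ncnc21` gives 10 nM. For the measured compounds named here, compound 2 `CCCn1c(-c2ccccc2)nc2c(NC3CCOC3)ncnc21` gives 25 nM, and the step of a 2.5-fold higher number from compound 1 to compound 2 (0.40 log units; beyond the scatter) is the only single-point change measured so far. Compound 3 `Cn1c(-c2ccc(O)cc2)nc2c(NC3CCCC3)ncnc21` gives 17 nM, the second highest of the three numbers, yet within the scatter of both compound 2 and compound 1, so these values alone set no order among the three.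

Compound 4 `Cn1c(-c2ccc(Cl)cc2)nc2c(NC3CCCC3)ncnc21` has not yet been measured. It differs from compound 3 by chloro in place of hydroxy on an aromatic carbon; the same difference, cut one bond further out, reads 4-hydroxyphenyl to 4-chlorophenyl. Going by the values given here, no measured pair shows this change: the one measured step concerns a different part of the molecule, and compound 1 and compound 3 differ in two places at once, so their values say little about the aryl group by itself. With nothing to anchor a direction, a step within the scatter is expected, a 1.1-fold lower number from compound 3 to compound 4 (0.05 log units; within the scatter). Compound 4 is therefore estimated at 15 nM, with a range from 5 nM to 50 nM.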

Compound 4, inhibition constant: 18 nM
Compound 4: middle estimate off by 1.2-fold (0.08 log units), on the low side; low and high end bracket the measured number.
By their numbers in this assay, from the lowest: compounds 1, 3, 4 and 2 (each within the scatter of the next, the first and the last beyond it).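

In this assay, for the compounds shown here, the exchange of hydroxy for chloro gives a 1.1-fold higher number from compound 3 to compound 4 (0.02 log units; within the scatter) and is the first direct reading of this position, an aromatic carbon para to a large group. A hydroxy, which counts as a hydrogen-bond donor and acceptor, and a chloro, which counts as neither, cannot be told apart here, so for this pair the donor and acceptor count on this carbon leaves no visible mark on the number. Nothing in the available data accounts for this result.

A single exchange cannot show whether this position accepts any group, so a plain hydrogen, an amine, a carboxylic acid or a longer chain such as butoxy at the same place could still read differently. From the compounds shown here alone, it also remains open whether the match between hydroxy and chloro would survive on a compound carrying the propyl chain of compound 1, or the oxolan-3-yl group of compound 2 in place of cyclopentyl, since this exchange has been read only on the methyl-bearing, cyclopentyl-bearing pair.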